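Ortho Trifluoromethyl Added to the Best Aryl Urea

This account rests on a few compounds, and the source may have more. Where it says the series, first, only, none or still open, it means among the compounds named here.

Three ureas built on the same oxadiazole-linked core have been measured in a functional assay on MDA-MB-231 cells (Homo sapiens) for antiproliferative activity, read by MTT assay, with a stated time of 72 h; on this read-out higher numbers stand for weaker inhibition and lower numbers for stronger inhibition. Compound 1 `O=C(Nc1cccc(-c2nc(-c3ccc(NC(=O)c4cccnc4)cc3Cl)no2)c1)Nc1cccc(C(F)(F)F)c1` gives 1900 nM. Compound 2 `NS(=O)(=O)Nc1ccc(NC(=O)Nc2cccc(-c3nc(-c4ccc(NC(=O)c5cccnc5)cc4Cl)no3)c2)cc1` gives 8900 nM, and compound 3 `CS(=O)(=O)Nc1ccc(NC(=O)Nc2cccc(-c3nc(-c4ccc(NC(=O)c5cccnc5)cc4Cl)no3)c2)cc1` gives 600 nM, the lowest number of the three. The steps confirm this order: a 4.7-fold higher number from compound 1 to compound 2 (0.67 log units; beyond the scatter), a 3.2-fold lower number from compound 1 to compound 3 (0.50 log units; beyond the scatter) and a 15-fold lower number from compound 2 to compound 3 (1.17 log units; beyond the scatter).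

Compound 4 `CS(=O)(=O)Nc1ccc(NC(=O)Nc2cccc(-c3nc(-c4ccc(NC(=O)c5cccnc5)cc4Cl)no3)c2)cc1C(F)(F)F` keeps the whole of compound 3 and adds one group: trifluoromethyl in place of hydrogen on an aromatic carbon. Among the measured compounds shown here, none of the measured steps places a group at this spot; the only trifluoromethyl measured stands in a different arrangement in compound 1, where the whole terminal aryl differs, so those steps do not map onto this one. The measured steps show that the terminal aryl tolerates several groups with modest movements, and a fresh substituent next to the methanesulfonamido is expected to shift the number only modestly, more likely upward than downward, with the possibility of no change beyond the scatter. Compound 4 is therefore expected to give 900 nM in this assay, in a range from 250 nM to 3200 nM. The expected step is a 1.5-fold higher number from compound 3 to compound 4 (0.18 log units; within the scatter).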

Compound 4, half-maximal inhibitory concentration: 700 nM
Compound 4: middle estimate off by 1.3-fold (0.11 log units), on the high side; the range from low to high includes it.
By their numbers in this assay, from the lowest: compounds 3 and 4 (each within the scatter of the next); then compound 1; then compound 2.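

The aromatic carbon ortho to a methanesulfonamido group carries only hydrogen in compound 3, and in this assay placing trifluoromethyl there gives a 1.2-fold higher number from compound 3 to compound 4 (0.07 log units; within the scatter), so this position takes these 4 heavy atoms with no change that can be told from the scatter. Compound 4 can also be read as compound 1 with a methanesulfonamido group added, which gives a 2.7-fold lower number from compound 1 to compound 4 (0.43 log units; beyond the scatter) and points the same way as a 3.2-fold lower number from compound 1 to compound 3 (0.50 log units; beyond the scatter), so among compounds 1, 3 and 4 the lower numbers go with the methanesulfonamido group, whether or not trifluoromethyl is on the ring. Nothing available explains why the number holds at this position.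

From the compounds shown here alone, whether chlorine, an amine or a carboxylic acid on this same aromatic carbon would also leave the number where it stands remains open. Among the compounds shown here, also open is how trifluoromethyl at this position behaves when amino replaces the methyl on the sulfonyl sulfur, the one change that separates compound 2 from compound 3.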